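The source may hold more compounds than are shown below. What is called first, only, known or untested is meant among the compounds shown, and "the series" means these compounds.

Measured compounds:
Compound 1, `Cc1ccnc(/C(N)=N/NC(=S)N2CCOCC2)c1`, gives 43.2%.
Compound 2, `Cc1ccnc(/C(N)=N/NC(=S)N2CCSCC2)c1`, gives 47.7%.
Compound 3, `N/C(=N\NC(=S)N1CCSCC1)c1ccc(F)cn1`, gives 55.1%.

All three numbers come from a functional assay on A-375 cells (Homo sapiens) for cytotoxicity, read by MTT assay, with a stated time of 72 h, tested at 1 uM; on this read-out lower numbers stand for less inhibition of growth and higher numbers for more inhibition of growth at the one concentration tested. Compound 1 and compound 2 share one core and differ only in one group: morpholin-4-yl in place of thiomorpholin-4-yl on a thiocarbonyl carbon. That change made a step of a number 4.5 percentage points lower from compound 2 to compound 1 (within the scatter), so the two numbers cannot be told apart. Compound 3 carries a different core; how its core differs from that of compound 2 is not broken down here. Its number stands above that of compound 1 by more than the usual spread of such measurements, while its gap to compound 2 is within that spread.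

Compound 4, `N/C(=N\NC(=S)N1CCOCC1)c1ccc(F)cn1`, is not yet measured. It is related to compound 3 exactly as compound 1 is to compound 2: morpholin-4-yl in place of thiomorpholin-4-yl on a thiocarbonyl carbon. Since that same change once produced a step within the scatter, a similar small step is expected here, namely a number 5.1 percentage points lower from compound 3 to compound 4 (within the scatter), resting on the step from compound 2 to compound 1. In this assay compound 4 is therefore expected to give about 50%, most likely between 38% and 61%.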

Compound 4, percent growth inhibition at one concentration: 44.5%
Estimate against measurement, compound 4: 5.5 percentage points above, and the stated range covers the measured number.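

Putting morpholin-4-yl in place of thiomorpholin-4-yl on the core of compound 3 gave a number 10.6 percentage points lower from compound 3 to compound 4 (beyond the scatter). Set beside the earlier case, the size of the step does not measurably depend on which of the two cores carries the change: the same change on two cores in this assay, a number 4.5 percentage points lower (within the scatter) from compound 2 to compound 1 and a number 10.6 percentage points lower (beyond the scatter) from compound 3 to compound 4, 6.1 percentage points apart, within the scatter of two such steps. In this assay, this means the earlier step was a fair guide for this one pair, but two pairs of compounds establish no rule for the whole series, and they do not explain why the numbers take these values.

The compounds shown leave open how other groups on the thiocarbonyl carbon would compare, such as piperidin-1-yl or an open-chain dimethylamino group. They also leave open whether the two steps would still match at other concentrations or in other cell types, since every number here comes from one concentration in one cell line.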